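Benzylic sulfanyl side chain: aromatic ring returns in place of cyclohexyl

The source may report more compounds than this note shows. Statements on the series, on what has been measured and on what is new or still open speak of the compounds shown alone.

Compound 1 `Cc1cc(Nc2cc(-c3ccccc3)[nH]n2)n2nc(SCc3nc4ccccc4[nH]3)nc2n1` and compound 2 `Cc1cc(Nc2cc(-c3ccccc3)[nH]n2)n2nc(SCc3ccccc3Br)nc2n1` share the core with compound 3 `Cc1cc(Nc2cc(-c3ccccc3)[nH]n2)n2nc(SCC3CCCCC3)nc2n1` and differ only in the group on the saturated chain carbon bound to the sulfur. In a functional assay on MCF7 cells (Homo sapiens) for inhibition, read by MTT assay, with a stated time of 72 h (a higher number here means a weaker inhibitor, a lower number a stronger inhibitor), compound 1 gives 2730 nM, and compound 2 gives 3020 nM; the pair differ by a 1.1-fold higher number from compound 1 to compound 2 (0.04 log units; within the scatter). Compound 3 reaches only a limit, > 50000 nM, which is the limit of > 50000 nM in this assay, at which 1 of the 3 values shown sits. The steps to it were large: an at least 18-fold higher number from compound 1 to compound 3 (1.26 log units; beyond the scatter) and an at least 16-fold higher number from compound 2 to compound 3 (1.21 log units; beyond the scatter). Compound 4 `COc1ccc(CSc2nc3nc(C)cc(Nc4cc(-c5ccccc5)[nH]n4)n3n2)cc1` makes the change (4-methoxyphenyl in place of cyclohexyl on a saturated chain carbon bound to a sulfur), which restores an aromatic ring on the chain. Since both aromatic analogues gave numbers far from the limit, a large step back downward is expected, an at least 16-fold lower number from compound 3 to compound 4 (1.22 log units; beyond the scatter). Compound 4 is estimated at 3000 nM, plausibly between 1000 nM and 12000 nM.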

Compound 4, half-maximal inhibitory concentration: 4020 nM
Estimate against measurement, compound 4: 1.3-fold (0.13 log units) below; the range from low to high includes it.
By their numbers in this assay, from the lowest: compounds 1, 2 and 4 (each within the scatter of the next). At a limit, above all of these: compound 3.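

In this assay, 4-methoxyphenyl in place of cyclohexyl on the saturated chain carbon bound to a sulfur gives an at least 12-fold lower number from compound 3 to compound 4 (1.09 log units; beyond the scatter). Compound 3 stands at a limit, so this step gives only a bound on the size of the change: the limit of > 50000 nM in this assay, at which 1 of the 4 values shown sits. Three different aromatic groups now lie within the scatter of one another, with a 1.3-fold higher number from compound 2 to compound 4 (0.12 log units; within the scatter) and a 1.5-fold higher number from compound 1 to compound 4 (0.17 log units; within the scatter), and among these four compounds only the cyclohexyl of compound 3 stands apart.

Still open, as far as these compounds go, is how an amine, a carboxylic acid or a longer chain on this carbon would compare with the aromatic groups and with cyclohexyl.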